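Chain Length and Amine Swap in Cinnamanilide Lipophilicity

This account rests on a few compounds, and the source may have more. Where it says the series, first, only, none or still open, it means among the compounds named here.

Measured compounds:
compound 1, `COc1cc(/C=C/C(=O)Nc2ccccc2)ccc1OCCCCCN(C)C`, 1.61;
compound 2, `COc1cc(/C=C/C(=O)Nc2ccccc2)ccc1OCCCCCCN1CCCC1`, 1.76;
compound 3, `CCN(CC)CCCCCCCCOc1ccc(/C=C/C(=O)Nc2ccccc2)cc1OC`, 1.75.

In a physicochemical assay for lipophilicity, using the shake flask method, measured as octanol-water partition, at pH 7.4 (on this read-out lower numbers stand for lower lipophilicity and higher numbers for higher lipophilicity), compound 3 sits within the scatter of both of its neighbours: the step of a number 0.01 log units lower from compound 2 to compound 3 (within the scatter) and the step of a number 0.14 log units higher from compound 1 to compound 3 (within the scatter) are both too small to count as real differences. Compound 4, `COc1cc(/C=C/C(=O)Nc2ccccc2)ccc1OCCCCCCCCCCN1CCCC1`, has not been measured in this assay. Relative to compound 3 it carries 2-(pyrrolidin-1-yl)ethyl in place of diethylamino on a saturated chain carbon, eight bonds along the chain from an oxygen on an aromatic ring. Going by the values given here, two measured steps bear on this change. The step of a number 0.01 log units lower from compound 2 to compound 3 (within the scatter) exchanged a pyrrolidinyl for a diethylaminoethyl group, the reverse pairing of the present one, and the step of a number 0.15 log units higher from compound 1 to compound 2 (within the scatter) moved from an open dialkylamino to a pyrrolidinyl group; neither left the scatter. Since the amine swap has so far been silent and the longer chain of compound 3 gave only the small step from compound 1, compound 4 is expected to show at most a modest shift, estimated as a number 0.20 log units higher from compound 3 to compound 4 (within the scatter). Compound 4 is therefore estimated at 1.95, within the range 1.45 to 2.45.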

Compound 4, partition coefficient: 1.86
The estimate for compound 4 lay 0.09 log units above the measured number; low and high end bracket the measured number.
By their numbers in this assay, from the lowest: compounds 1, 3, 2 and 4 (each within the scatter of the next).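

With the amine ring kept, 4-(pyrrolidin-1-yl)butyl in place of pyrrolidin-1-yl gave a number 0.10 log units higher from compound 2 to compound 4 (within the scatter) in this assay; this is the only step among these compounds that alters the chain while leaving the amine unchanged. The swap of diethylamino for 2-(pyrrolidin-1-yl)ethyl gave a number 0.11 log units higher from compound 3 to compound 4 (within the scatter) and even 5-(pyrrolidin-1-yl)pentyl in place of dimethylamino gave a number 0.25 log units higher from compound 1 to compound 4 (within the scatter), so no change at this position has yet left the scatter, whether it alters the chain alone or the chain and amine together. No available data offer an explanation for these small steps.

The compounds shown leave open whether a still longer chain would move the number beyond the scatter. They also leave open what a piperidine, a morpholine or a carboxylic acid at the chain end would do.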